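Methoxy to ethoxy on compound 1

The compounds below may be only part of what the source reports. "The series", "measured", "known", "first", "only" and "open" are said of these compounds alone.

Measured in a functional assay on DU-145 cells (Homo sapiens) for cytotoxicity, read by MTT assay, with a stated time of 72 h (a higher number here means that more compound is needed for the effect, a lower number that less compound is needed), so far:
- compound 1 `CCc1cccc2c(OC)c(-c3occ(C)c3C(=O)OC)ccc12` gives 2.2 ug/mL
- compound 2 `CCc1cccc2c(OC)c(-c3occ(C)c3C(=S)OC)ccc12` gives 5.7 ug/mL
- compound 3 `CCc1cccc2c(OC)c(-c3occ(C)c3C(=O)On3nnc4ccccc43)ccc12` gives > 10 ug/mL, which is a limit and not a number

Compound 1 holds the lowest value in this assay, and compound 2 is its nearest neighbour among the numbers. Compound 3 stands at a limit, (the limit of > 10 ug/mL in this assay, at which 1 of the 3 values shown sits).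

Compound 4 `CCOc1c(-c2occ(C)c2C(=O)OC)ccc2c(CC)cccc12` differs from compound 1 by a single change: methyl in place of hydrogen on a saturated chain carbon bound to an oxygen on an aromatic ring. This places methyl in place of hydrogen on a saturated chain carbon bound to an oxygen on an aromatic ring, so methoxy becomes ethoxy.

Among the measured compounds shown here, no measured step touches this place, so the evidence is only indirect. Two changes made elsewhere on compound 1 are known: a 2.6-fold higher number from compound 1 to compound 2 (0.41 log units; beyond the scatter) and an at least 4.5-fold higher number from compound 1 to compound 3 (0.65 log units; beyond the scatter). Both raised the number. For the measured compounds named here, a small step is therefore expected for this minimal change, more likely upward than downward, since compound 1 at 2.2 ug/mL is the lowest value so far. The expected step is a 1.4-fold higher number from compound 1 to compound 4 (0.13 log units; within the scatter). For compound 4 the estimated value is 3 ug/mL, with an expected range from 1.2 ug/mL to 7.5 ug/mL.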

Compound 4, concentration for half-maximal effect: 1.9 ug/mL
Compound 4: the middle estimate sits 1.6-fold (0.20 log units) above what was measured; the range from low to high includes it.
By their numbers in this assay, from the lowest: compounds 4 and 1 (each within the scatter of the next); then compound 2. At a limit, above all of these: compound 3.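

In this assay the change from methoxy to ethoxy gives a 1.2-fold lower number from compound 1 to compound 4 (0.06 log units; within the scatter). Among the compounds shown here, this is the only direct reading at this place, and it shows that a methyl added on the saturated chain carbon bound to an oxygen on an aromatic ring leaves the number within the scatter of compound 1, in contrast to the change elsewhere on compound 1 that gives a 2.6-fold higher number from compound 1 to compound 2 (0.41 log units; beyond the scatter). Nothing at hand bears on why this added methyl leaves the number so little moved.

The compounds shown leave open how far this place accepts further change: a longer chain such as propoxy, a branched one such as isopropoxy, a free hydroxyl or a chain ending in an amine could each behave differently from ethoxy, and a single step says nothing about where the flat stretch ends. From the compounds shown here alone, it also stays open whether ethoxy behaves the same way when combined with the thiocarbonyl of compound 2, since the two changes are seen here only separately on the core of compound 1.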